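Changing the aryl group on the amine nitrogen of the core

The source may report more compounds than this note shows. Statements on the series, on what has been measured and on what is new or still open speak of the compounds shown alone.

Compound 1 `COc1cc2ncnc(Nc3ccc(F)cc3)c2cc1OCCCCC(=O)Nc1ccc(S(N)(=O)=O)cc1` gives > 40000 nM in a functional assay on NCI-H1975 cells (Homo sapiens) for antiproliferative activity, read by MTT assay, with a stated time of 72 h; on this read-out higher numbers stand for weaker inhibition and lower numbers for stronger inhibition; this value is a limit of the assay, not a number.
Compound 2 `COc1cc2ncnc(Nc3cccc(C)c3)c2cc1OCCCCC(=O)Nc1ccc(S(N)(=O)=O)cc1` gives 32100 nM in this assay.

Compound 2 holds the only actual number shown; the other value is a limit, because compound 1 sits at the limit of > 40000 nM in this assay, at which 1 of the 2 values shown sits. Among the measured compounds shown here, the one measured step, an at least 1.2-fold lower number from compound 1 to compound 2 (0.09 log units; that floor lies within the scatter), has a floor that lies within the usual scatter, so it reveals no clear difference between the two aryl groups on that nitrogen. Compound 3 `COc1ccccc1Nc1ncnc2cc(OC)c(OCCCCC(=O)Nc3ccc(S(N)(=O)=O)cc3)cc12` carries a further change at the same place: 2-methoxyphenyl in place of 3-methylphenyl on a nitrogen on an aromatic ring. For the measured compounds named here, the only step that bears on it is the one just described, and it was small, so the expected step of a 1.1-fold lower number from compound 2 to compound 3 (0.03 log units; within the scatter) is none beyond the scatter. Compound 3 is therefore estimated at 30000 nM in this assay, with a range from 10000 nM to 90000 nM, and a limit rather than a number would not be surprising.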

Compound 3, half-maximal inhibitory concentration: 8030 nM
Compound 3: the middle estimate sits 3.7-fold (0.57 log units) above what was measured; measured number outside the range, below it.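

Among the compounds shown here, replacing 3-methylphenyl with 2-methoxyphenyl on this nitrogen gives a 4.0-fold lower number from compound 2 to compound 3 (0.60 log units; beyond the scatter) in this assay, the first step that clearly separates two aryl groups at this place. Replacing 4-fluorophenyl with 2-methoxyphenyl gives an at least 4.9-fold lower number from compound 1 to compound 3 (0.69 log units; beyond the scatter), which also lies beyond the scatter. Compound 1 holds a limit of the assay and not a number, so this second step is only a floor: the limit of > 40000 nM in this assay, at which 1 of the 3 values shown sits.

Compound 3 differs from compound 2 both in the group on the ring and in where it sits, so the compounds shown cannot separate these two changes, which a 3-methoxyphenyl or a 2-methylphenyl group would help to do. Going by these compounds, it also remains open whether a 2-ethoxyphenyl or a 2-chlorophenyl group at this place would give a lower number still.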